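This account rests on a few compounds, and the source may have more. Where it says the series, first, only, none or still open, it means among the compounds named here.

Compound 1 `CNC(=O)c1nc(-c2cc(OC)c(OC)c(OC)c2)n(-c2ccc(OC)cc2)n1` gives 109% in a functional assay on the whole organism for inhibition, with Rattus norvegicus as the target, read by paw edema, with stated times of 30 min and 3 h, at a dose of 0.28 mmol/kg by the oral route; a higher number here means more inhibition at the dose given (going by the name of the read-out), a lower number less inhibition.
Compound 2 `COc1ccc(-n2nc(C(=O)Nc3ccccc3C)nc2-c2cc(OC)c(OC)c(OC)c2)cc1` gives 74% in this assay.

Compound 2 stands lowest of the two numbers, with compound 1 the nearer one and well beyond the scatter above it. Compound 3 `COc1ccc(-n2nc(C(=O)Nc3cccc(F)c3)nc2-c2cc(OC)c(OC)c(OC)c2)cc1` differs from compound 2 by 3-fluorophenyl in place of 2-methylphenyl on an amide-type nitrogen. Going by the values given here, the only step measured, a number 35 percentage points lower from compound 1 to compound 2 (beyond the scatter), exchanges a methyl for a 2-methylphenyl on that nitrogen; no measured step exchanges one such ring-bearing group for another, so its size cannot be read from these numbers. Compound 3 is expected to stay close to compound 2, a step of a number 4 percentage points higher from compound 2 to compound 3 (within the scatter). The estimate for compound 3 in this assay is 78%, ranging from 55% to 100%.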

Compound 3, a percentage reported as inhibition, in the whole organism at one dose (the size of the read-out at that dose, not a potency): 106%
The estimate for compound 3 lay 28 percentage points below the measured number, outside the stated range (above it).
By their numbers in this assay, from the lowest: compound 2; then compounds 3 and 1 (each within the scatter of the next).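

The ring on this amide nitrogen is not a neutral choice: 3-fluorophenyl in place of 2-methylphenyl gives a number 32 percentage points higher from compound 2 to compound 3 (beyond the scatter) in this assay. A ring here therefore need not cost inhibition, since 3-fluorophenyl in place of methyl gives a number 3 percentage points lower from compound 1 to compound 3 (within the scatter) and the loss seen with compound 2 belongs to the 2-methylphenyl group rather than to every ring. Nothing available explains this difference.

Two things changed together between these rings, the substituent and its place. Plain phenyl, 3-methylphenyl or 2-fluorophenyl on this nitrogen would separate them.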